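A few compounds are considered here, and "the series" means these few. Any claim that something is new, unique, unknown or untested is made for them only; others in the source may bear on it.

Measured so far:
compound 1 `CSc1ncnc2c1c(-c1ccccc1)cn2[C@@H]1O[C@H](CO)[C@@H](O)[C@H]1O` — > 20000 nM
compound 2 `Cc1nc(N)c2c(I)cn([C@@H]3O[C@H](CO)[C@@H](O)[C@H]3O)c2n1` — > 20000 nM

In a functional assay on HCT-116 cells (Homo sapiens), read by MTT assay, with a stated time of 72 h (on this read-out lower numbers stand for stronger inhibition and higher numbers for weaker inhibition), compound 1 gives > 20000 nM; this is a limit of the assay, not a number. In this assay compound 2 gives > 20000 nM, which is again only a limit. Compound 1 therefore stands at the limit of > 20000 nM in this assay, at which 2 of the 2 values shown sit, with no measured number in the series to set it against. Compound 3 `COc1ncnc2c1c(-c1ccccc1)cn2[C@@H]1O[C@H](CO)[C@@H](O)[C@H]1O` has not been measured; it differs from compound 1 by methoxy in place of methylsulfanyl on an aromatic carbon. Among the compounds with values here, no pair of measured compounds differs in one place, so no measured step gives a size for a change of this kind. With compound 1 at the limit of this assay, the expectation for the step is none beyond the scatter, and most likely another limit. The expected step that the limit leaves unreadable from compound 1 to compound 3 is accordingly taken as small. For compound 3 the estimate is 30000 nM, with a range from 10000 nM to 100000 nM, and a limit rather than a number is the expected outcome.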

Compound 3, half-maximal inhibitory concentration: > 20000 nM
Compound 3 gave a limit, no number; the forecaster's own chance of this, stated with the estimate: 85%; the middle value is on the limit's open side.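

No step can be read between compound 1 and compound 3, since both values in this assay are limits and not numbers: the limit of > 20000 nM in this assay, at which 3 of the 3 values shown sit.

The compounds shown leave open whether any change to the shared core brings a value within the readable range of this assay.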